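Dimethylsulfamoyl to dimethylcarbamoyl on the amine nitrogen

This account rests on a few compounds, and the source may have more. Where it says the series, first, only, none or still open, it means among the compounds named here.

Three compounds of the series carry a value in an assay on isolated protein for displacement of a labelled ligand from 5-hydroxytryptamine receptor 6 (Homo sapiens); a higher number here means a weaker inhibitor, a lower number a stronger inhibitor. Compound 1 `CC(=N)NCC1CCCc2cc(S(=O)(=O)c3ccccc3)ccc21` gives 0.631 nM. Compound 2 `CNC[C@@H]1CCCc2cc(S(=O)(=O)c3cc[nH]c3)ccc21` gives 0.159 nM, the lowest number of the three. Compound 3 `CN(C)S(=O)(=O)NC[C@@H]1CCCc2cc(S(=O)(=O)c3cccc(F)c3)ccc21` gives 2 nM, the highest number of the three; its gap to compound 1 and its gap to compound 2 both lie beyond the scatter, so compound 3 stands as the weakest inhibitor among the measured compounds. Among the measured compounds shown here, the three differ from one another in more than one place, so no single-point step connects any pair of them and none is drawn here.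

Compound 4 `CN(C)C(=O)NC[C@@H]1CCCc2cc(S(=O)(=O)c3cccc(F)c3)ccc21` is not yet measured. It differs from compound 3 in one place: dimethylcarbamoyl in place of dimethylsulfamoyl on an amine nitrogen. For the measured compounds named here, nothing among the measured compounds isolates this change, since no measured pair differs only there, so the expectation rests on compound 3 alone and on the small size of the change. The expected step is a 1.5-fold higher number from compound 3 to compound 4 (0.18 log units; within the scatter) in this assay, which is none beyond the scatter, with a slight lean toward a higher number. Compound 4 is therefore estimated at 3 nM, with a range from 1 nM to 9 nM.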

Compound 4, inhibition constant: 2.51 nM
The estimate for compound 4 lay 1.2-fold (0.08 log units) above the measured number; the range from low to high includes it.
By their numbers in this assay, from the lowest: compound 2; then compound 1; then compounds 3 and 4 (each within the scatter of the next).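

In this assay, the series now has its first single-point step: a 1.3-fold higher number from compound 3 to compound 4 (0.10 log units; within the scatter) shows that, with the rest of the molecule unchanged, dimethylcarbamoyl and dimethylsulfamoyl cannot be told apart on this amine nitrogen. The exchange takes the group from 6 heavy atoms to 5 and from 2 hydrogen-bond acceptors to 1, and removes the sulfur, yet the step stays within the scatter, so this position accepts either group on this core without a readable change in the number. No supporting measurement bears on why the two groups read alike.

Going by these compounds, it remains open whether other groups on this nitrogen, such as acetyl, methanesulfonyl or a free amine, would stay within the scatter of compounds 3 and 4, and whether the two groups would also read alike with a different aryl group on the sulfone. Compound 1 and compound 2 differ from compounds 3 and 4 in more than one place, so they cannot yet show how the substituent on this nitrogen acts on its own.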